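The source may report more compounds than this note shows. Statements on the series, on what has been measured and on what is new or still open speak of the compounds shown alone.

Working notes on the series. In a functional assay on SK-MEL-5 cells (Homo sapiens) for inhibition, with a stated time of 48 h (on this read-out lower numbers stand for stronger inhibition of growth and higher numbers for weaker inhibition of growth), compound 1 `COc1c(C(=O)/C=C/c2ccc(Cl)cc2)c(O)c(Br)c2occc12` gives 3330 nM and compound 2 `C=CCc1c(O)c(C(=O)/C=C/c2ccccc2)c(OC)c2ccoc12` gives 2660 nM. These two values lie within the scatter of each other, so compound 2 stands level with compound 1 on this assay. Compound 3 `C=CCc1c(O)c(C(=O)/C=C/c2ccc(Cl)cc2)c(OC)c2ccoc12` keeps the core of compound 2 and carries one change: chloro in place of hydrogen on an aromatic carbon. This is chloro in place of hydrogen on an aromatic carbon, phenyl to 4-chlorophenyl. Among the compounds with values here, no measured pair isolates this change, so nothing yet fixes its size or direction. A small shift towards a lower number is expected, and probably none beyond the scatter. The estimated change is a 1.2-fold lower number from compound 2 to compound 3 (0.08 log units; within the scatter). For compound 3 the expected value is 2200 nM, with an estimated range of 900 nM to 5000 nM.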

Compound 3, concentration for 50% growth inhibition: 2070 nM
For compound 3 the middle estimate is 1.1-fold (0.03 log units) above the measured one; measured number inside the range.
By their numbers in this assay, from the lowest: compounds 3, 2 and 1 (each within the scatter of the next).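

In this assay the change from phenyl to 4-chlorophenyl now has a measured pair: a 1.3-fold lower number from compound 2 to compound 3 (0.11 log units; within the scatter) lies within the scatter, so chloro in place of hydrogen, para to a large group, leaves compound 3 level with compound 2. Allyl in place of bromo on an aromatic carbon also has its first measured pair, and a 1.6-fold lower number from compound 1 to compound 3 (0.21 log units; within the scatter) lies within the scatter as well, leaving compound 3 level with compound 1. No measurement at hand offers an explanation for either result.

Still open, from the compounds shown here alone, is whether an amine or a carboxylic acid in place of chloro, or a longer chain in place of allyl, would move the number beyond the scatter. Going by these compounds, whether the chloro step holds on the bromo-bearing core of compound 1 also stays open.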